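Chloro on the Styryl Ring: Expected Half-Life Unchanged

The source may report more compounds than this note shows. Statements on the series, on what has been measured and on what is new or still open speak of the compounds shown alone.

Compound 2 `NS(=O)(=O)c1cc(-c2nnc(/C=C/c3ccccc3)o2)c(Cl)cc1SCc1ccccc1` gives 0.228 h in an ADME assay on microsomes from liver (Homo sapiens) for metabolic stability, read by LC-MS, using NADPH, tested at 5 uM (on this read-out higher numbers stand for a longer-lived compound and lower numbers for a shorter-lived compound), the higher of the two numbers measured; compound 1 `CCOC(=O)c1cn(Cc2nnc(-c3cc(S(N)(=O)=O)c(SCc4ccccc4)cc3Cl)o2)nn1` gives 0.085 h, and the step of a 2.7-fold higher number from compound 1 to compound 2 (0.43 log units; beyond the scatter) exchanged an entire group on the shared core. Compound 3 `NS(=O)(=O)c1cc(-c2nnc(/C=C/c3cccc(Cl)c3)o2)c(Cl)cc1SCc1ccccc1` differs from compound 2 by chloro in place of hydrogen on an aromatic carbon, sitting on an aromatic carbon of a six-membered aromatic ring of carbon only. Among the compounds with values here, no measured step touches that ring, so the one step measured so far does not speak to this change. Compound 3 is therefore expected to show no step beyond the scatter, a 1.1-fold higher number from compound 2 to compound 3 (0.04 log units; within the scatter). The estimate for compound 3 is 0.25 h, within 0.12 h to 0.5 h.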

Compound 3, half-life: 0.352 h
The estimate for compound 3 lay 1.4-fold (0.15 log units) below the measured number; low and high end bracket the measured number.
By their numbers in this assay, from the lowest: compound 1; then compounds 2 and 3 (each within the scatter of the next).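

In this assay, within the data shown here, this is the first reading on the phenyl ring of the 2-phenylethenyl group: phenyl to 3-chlorophenyl gives a 1.5-fold higher number from compound 2 to compound 3 (0.19 log units; within the scatter) and so leaves the number within the scatter. Exchanging the whole group on the shared core still registers, with a 4.1-fold higher number from compound 1 to compound 3 (0.62 log units; beyond the scatter) as the step beyond the scatter. No measured evidence bears on either step. From the compounds shown here alone, whether an amine or a carboxylic acid in place of chloro at this position would give a step beyond the scatter remains open, as does the effect of chloro elsewhere on that ring.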